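Swapping Chloro for Methoxy Between Two Assay Limits

This account rests on a few compounds, and the source may have more. Where it says the series, first, only, none or still open, it means among the compounds named here.

Compound 1 `O=C(Nc1cccc(-c2nc3ccccc3s2)c1)c1cc([N+](=O)[O-])ccc1Cl`: > 27000 nM (a limit)
Compound 2 `O=C(Nc1ccc(Cl)c(-c2nc3ccccc3s2)c1)c1cc([N+](=O)[O-])ccc1Cl`: > 25000 nM (a limit)

In an ADME assay on Raji cells (Homo sapiens) for cytotoxicity, with a stated time of 72 h (a higher number here means that more compound is needed for the effect, a lower number that less compound is needed), compound 2 gives > 25000 nM, which is a limit and not a number. In this assay compound 1 gives > 27000 nM, which is also a limit. Among the measured compounds shown here, the only measured step is a step that the two limits leave unreadable from compound 1 to compound 2, so it offers no size to carry forward.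

Compound 3 `COc1ccc(NC(=O)c2cc([N+](=O)[O-])ccc2Cl)cc1-c1nc2ccccc2s1` differs from compound 2 by one change: methoxy in place of chloro on an aromatic carbon. This places methoxy in place of chloro on an aromatic carbon, ortho to a 1,3-benzothiazol-2-yl group and para to a large group.

With no readable step as a guide, the expected result is no shift beyond the usual scatter, and this assay may well report only a limit again. The estimated step is a number no higher from compound 2 to compound 3 (the limit leaves the size open). Compound 3 is expected at 25000 nM, with an estimated range from 8000 nM to 50000 nM.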

Compound 3, half-maximal effective concentration: > 25000 nM
Compound 3: a limit, no number; the forecaster's own chance of this, stated with the estimate: 80%; the middle value lies on the limit itself.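

In this assay, among the compounds shown here, compound 1, compound 2 and compound 3 all give limits and not numbers, and no step among them can be read. Left open is how much of each is needed for the effect, and whether chloro or methoxy on the aromatic carbon changes that amount.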